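Replacing dimethylamino with piperidin-1-yl in compound 3

The compounds below may be only part of what the source reports. "The series", "measured", "known", "first", "only" and "open" are said of these compounds alone.

In an ADME assay on L6 cells (Rattus norvegicus) for cytotoxicity (a higher number here means a weaker inhibitor, a lower number a stronger inhibitor), compound 1 `OC1CC2(N3CCCC3)CC(c3ccc(Cl)cc3)C1C(c1ccc(Cl)cc1)C2` gives 3590 nM and compound 2 `OC1CC2(N3CCCCC3)CC(c3ccc(Cl)cc3)C1C(c1ccc(Cl)cc1)C2` gives 11600 nM. Compound 3 `CN(C)C12C/C(=N\O)C(C(c3ccc(Cl)cc3)C1)C(c1ccc(Cl)cc1)C2` gives 7820 nM, a number within the usual scatter of compound 2 and beyond the scatter above compound 1.

Compound 4 `O/N=C1\CC2(N3CCCCC3)CC(c3ccc(Cl)cc3)C1C(c1ccc(Cl)cc1)C2` has not been measured yet. It is compound 3 with piperidin-1-yl in place of dimethylamino on a saturated ring carbon.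

Among the measured compounds shown here, only one measured step bears on this change, and it is an imperfect guide. It also brings in piperidin-1-yl, but it replaces pyrrolidin-1-yl rather than dimethylamino, and compounds 1 and 2 carry a hydroxyl group where compounds 3 and 4 carry an oxime. For the measured compounds named here, no measured pair starts from dimethylamino. Going by compound 2 and its step, a 3.2-fold higher number from compound 1 to compound 2 (0.51 log units; beyond the scatter), a small rise in the number in this assay is expected, though it may well stay within the scatter.

The expected step is a 1.5-fold higher number from compound 3 to compound 4 (0.19 log units; within the scatter). The estimated value for compound 4 is 12000 nM, with an expected range from 4500 nM to 32000 nM.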

Compound 4, half-maximal inhibitory concentration: 8750 nM
Estimate against measurement, compound 4: 1.4-fold (0.14 log units) above; the range from low to high includes it.
By their numbers in this assay, from the lowest: compound 1; then compounds 3, 4 and 2 (each within the scatter of the next).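

In this assay, exchanging dimethylamino, which has no ring, for piperidin-1-yl, with its six-membered non-aromatic ring, on this saturated ring carbon gives a 1.1-fold higher number from compound 3 to compound 4 (0.05 log units; within the scatter), so the two amines cannot be told apart in this read-out when the oxime is present. The earlier step, a 3.2-fold higher number from compound 1 to compound 2 (0.51 log units; beyond the scatter), did separate two ring amines at this position, but it started from pyrrolidin-1-yl and carried a hydroxyl group instead of the oxime, so the new result shows that a change of amine here does not always move the number beyond the scatter. No measurement at hand explains why one amine change shifts the number and the other does not.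

On these data alone, it remains open whether pyrrolidin-1-yl would stand apart from piperidin-1-yl on the oxime compounds as it does on the hydroxyl compounds, and whether dimethylamino would match piperidin-1-yl on the hydroxyl compounds. A morpholine ring or an unsubstituted primary amine at this position would show whether the number stays in this range when the amine itself is changed further.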